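The source may report more compounds than this note shows. Statements on the series, on what has been measured and on what is new or still open speak of the compounds shown alone.

Of the compounds shown here, three have been measured so far in a functional assay on A549 cells (Homo sapiens) for cytotoxicity, read by MTT assay, with a stated time of 72 h (a lower number here means a stronger inhibitor, a higher number a weaker inhibitor), and they give a first reference point. Compound 1 `CN(C)Cc1ccc2nc(NC(=O)N/N=C/c3cn(Cc4ccccc4Cl)c4ccccc34)sc2c1` gives 1080 nM and is the strongest of the three. Compound 2 `CC1CCN(Cc2ccc3nc(NC(=O)N/N=C/c4c[nH]c5ccccc45)sc3c2)CC1` gives 3580 nM and compound 3 `CC1CCN(Cc2ccc3nc(NC(=O)N/N=C4\C(=O)Nc5ccc(F)cc54)sc3c2)CC1` gives 3010 nM, and both numbers are higher than that of compound 1 by more than the usual scatter of repeated measurements. Going by the values given here, these three compounds differ from one another in more than one place, so no measured pair isolates the effect of a single change.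

Compound 4 `Cc1ccc(Cn2cc(/C=N/NC(=O)Nc3nc4ccc(CN(C)C)cc4s3)c3ccccc32)cc1` has not yet been measured. It differs from compound 1 in one place only: 4-methylphenyl in place of 2-chlorophenyl on a saturated chain carbon bound to an aromatic nitrogen. In words, this is 4-methylphenyl in place of 2-chlorophenyl on a saturated chain carbon bound to an aromatic nitrogen. Among the compounds with values here, the rest of the molecule stays the same, and no measured compound tests this swap on its own. The expectation therefore rests on compound 1 at 1080 nM and is for little movement in this assay, with no firm direction. The estimated step is a 1.2-fold higher number from compound 1 to compound 4 (0.08 log units; within the scatter) and stays within the scatter, leaning slightly towards a weaker inhibitor. For compound 4 the expected value is 1300 nM (estimated range 500 nM to 3400 nM).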

Compound 4, half-maximal inhibitory concentration: 1600 nM
Beside the measured number, compound 4's estimate is 1.2-fold (0.09 log units) below it; the range from low to high includes it.
By their numbers in this assay, from the lowest: compounds 1, 4, 3 and 2 (each within the scatter of the next, the first and the last beyond it).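

Going by these compounds alone, this is the first pair of compounds that differ in one place only: on a saturated chain carbon bound to an aromatic nitrogen, 4-methylphenyl in place of 2-chlorophenyl gives in this assay a 1.5-fold higher number from compound 1 to compound 4 (0.17 log units; within the scatter) and so leaves the two compounds indistinguishable. The swap alters both the substituent on the ring and, going by the group names, where it sits, yet for this one pair the read-out gives no sign that either alteration matters. Nothing available explains this result.

From the compounds shown here alone, with both alterations made at once, it remains open whether each would also go unnoticed alone, and 4-chlorobenzyl or 2-methylbenzyl would pull them apart. It is also unknown how far this tolerance extends, for example to an unsubstituted benzyl group or to a benzyl group carrying an amine or a carboxylic acid on its ring.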